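Changing one side chain on a shared core

A few compounds are considered here, and "the series" means these few. Any claim that something is new, unique, unknown or untested is made for them only; others in the source may bear on it.

In a functional assay on PC-3 cells (Homo sapiens) for inhibition, with a stated time of 72 h (a higher number here means a weaker inhibitor, a lower number a stronger inhibitor), compound 1 (`Cc1nc(-c2nc[nH]n2)ccc1-c1cnc2c(n1)N(C1CCOCC1)C(=O)CN2`) gives 102 nM while compound 2 (`Cc1nc(-c2nc[nH]n2)ccc1-c1cnc2c(n1)N(C(C)C)C(=O)CN2`) gives 149 nM on the same test. Going by the values given here, these two numbers lie within the usual scatter of repeat measurements, so compound 2 stands level with the only other compound measured so far. Among the compounds with values here, compound 3 (`COCCN1C(=O)CNc2ncc(-c3ccc(-c4nc[nH]n4)nc3C)nc21`) keeps the shared core and has 2-methoxyethyl in place of isopropyl on an amide-type nitrogen in a ring as its single change. Within the data shown here, the only measured swap at this place gave a 1.5-fold higher number from compound 1 to compound 2 (0.16 log units; within the scatter) when isopropyl replaced oxan-4-yl. On that single step, no change beyond the scatter is expected in this assay for the new chain, though one step is thin evidence. The estimate is therefore a 1.1-fold lower number from compound 2 to compound 3 (0.06 log units; within the scatter) and no real shift in either direction. Compound 3 is expected at about 130 nM with an estimated range from 60 nM up to 280 nM in this test.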

Compound 3, half-maximal inhibitory concentration: 137 nM
Estimate against measurement, compound 3: 1.1-fold (0.02 log units) below; low and high end bracket the measured number.
By their numbers in this assay, from the lowest: compounds 1, 3 and 2 (each within the scatter of the next).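

Adding an oxygen and a hydrogen-bond acceptor to the chain on this amide-type nitrogen does not separate the compounds in this assay: the swap from isopropyl to 2-methoxyethyl gives a 1.1-fold lower number from compound 2 to compound 3 (0.04 log units; within the scatter). The swap from oxan-4-yl to 2-methoxyethyl gives a 1.3-fold higher number from compound 1 to compound 3 (0.13 log units; within the scatter), so isopropyl, 2-methoxyethyl and oxan-4-yl all stand level here, whether the group carries a ring or not, and whether it carries an oxygen or not. Nothing available explains why these three groups read alike.

On these data alone, all three groups are uncharged, so it remains open whether this position would accept an amine or a carboxylic acid just as readily. A much longer chain, or a bare hydrogen on this nitrogen, could also show whether the level readings have a limit.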